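Porcupine series: nitro removal on the benzothiazole of compound 1

The source may hold more compounds than are shown below. What is called first, only, known or untested is meant among the compounds shown, and "the series" means these compounds.

Measured compounds:
- compound 1, `O=C(CNC(=O)c1nn(-c2ccccc2)c(=O)c2ccccc12)Nc1nc2ccc([N+](=O)[O-])cc2s1` — 240 nM
- compound 2, `O=C(CSc1nc2c(c(=O)n1-c1ccccc1)SCC2)Nc1nc(-c2ccccc2)cs1` — 350 nM

In an assay on L cells for inhibition of Protein-serine O-palmitoleoyltransferase porcupine (Mus musculus), read by reporter gene assay, with a stated time of 24 h (a lower number here means that less compound is needed, a higher number that more compound is needed for the effect), compound 1 gives 240 nM. In this assay compound 2 gives 350 nM. Compound 1 has the lower of the two numbers, but its gap to compound 2 lies within the scatter, so the two compounds cannot be separated on these values. The two share no single-point difference, so nothing can be said about what drives the gap between them.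

Compound 3, `O=C(CNC(=O)c1nn(-c2ccccc2)c(=O)c2ccccc12)Nc1nc2ccccc2s1`, is the next compound to be measured. It differs from compound 1 only as follows: hydrogen in place of nitro on an aromatic carbon. There is no measured step of this kind in the series to lean on, so the expectation rests on compound 1 alone.

The step from compound 1 to compound 3 is expected to be a modest rise in the number, a 2.1-fold higher number from compound 1 to compound 3 (0.32 log units; beyond the scatter), that may or may not clear the scatter. For compound 3 the estimated value in this assay is 500 nM, with a range from 150 nM to 1700 nM.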

Compound 3, half-maximal effective concentration: 2600 nM
The estimate for compound 3 lay 5.2-fold (0.72 log units) below the measured number; measured number above the stated range.
By their numbers in this assay, from the lowest: compounds 1 and 2 (each within the scatter of the next); then compound 3.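

In this assay, for the compounds shown here, the change from 6-nitro-1,3-benzothiazol-2-yl to 1,3-benzothiazol-2-yl gives the only single-point comparison so far, and it is a large step: an 11-fold higher number from compound 1 to compound 3 (1.03 log units; beyond the scatter). This position on the six-membered aromatic ring is therefore far from indifferent, since with the rest of compound 1 held fixed, this one substitution accounts for the whole gap, and the nitro group is tied to the lower number in this pair. Nothing measured here explains why the number moves with this change.

A single pair cannot show whether the lower number is particular to nitro or would also appear with another group at this position, such as an amine, a nitrile, a methoxy group or a fluorine atom, nor whether nitro would give the same number elsewhere on this ring. Also open, as far as these compounds go, is whether the step carries over to other compounds, as compound 2 differs from compound 1 in more than one place and offers no comparison for this change.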